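From 4-acetylphenyl to 2-nitrophenyl on a shared core

The source may hold more compounds than are shown below. What is called first, only, known or untested is meant among the compounds shown, and "the series" means these compounds.

- Compound 1 `Cc1ccc(N2CCN(C(=S)SCc3ccc4nc(N)nc(N)c4c3)CC2)c(C)c1`: 3000 nM
- Compound 2 `CC(=O)c1ccc(N2CCN(C(=S)SCc3ccc4nc(N)nc(N)c4c3)CC2)cc1`: 2550 nM

Both numbers come from a functional assay on A549 cells (Homo sapiens) for antiproliferative activity, read by MTT assay, with a stated time of 72 h; a lower number here means a stronger inhibitor, a higher number a weaker inhibitor. In this assay compound 2 gives 2550 nM. Going by the values given here, only one other compound has been measured, and the two lie within the usual scatter of repeated measurements, so they cannot be ranked.

The next compound, compound 3 `Nc1nc(N)c2cc(CSC(=S)N3CCN(c4ccccc4[N+](=O)[O-])CC3)ccc2n1`, keeps the shared core and carries 2-nitrophenyl in place of 4-acetylphenyl on an amine nitrogen in a ring.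

Among the compounds with values here, one measured step bears on this change, since it altered the group at the same place: a 1.2-fold lower number from compound 1 to compound 2 (0.07 log units; within the scatter). That swap of 2,4-dimethylphenyl for 4-acetylphenyl left the number within the scatter. Within the data shown here, a single step is thin evidence, and no compound with a nitro group has been measured yet. Even so, the expectation in this assay is no change beyond the scatter, in either direction. The expected size of the change is a 1.0-fold lower number from compound 2 to compound 3 (0.01 log units; within the scatter). For compound 3 the estimated value is 2500 nM, with an expected range from 900 nM to 7000 nM.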

Compound 3, half-maximal inhibitory concentration: 4360 nM
Estimate against measurement, compound 3: 1.7-fold (0.24 log units) below, within the range that was stated.
By their numbers in this assay, from the lowest: compounds 2, 1 and 3 (each within the scatter of the next).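

Going by these compounds alone, replacing 4-acetylphenyl with 2-nitrophenyl puts a nitro group at this position for the first time, yet in this assay the step stays within the scatter (a 1.7-fold higher number from compound 2 to compound 3 (0.23 log units; within the scatter)), and the same holds for the change from 2,4-dimethylphenyl (a 1.5-fold higher number from compound 1 to compound 3 (0.16 log units; within the scatter)). The position on the ring nitrogen now carries three differently substituted phenyl groups, with methyl, acetyl and nitro substituents, and the numbers do not separate any of them, so none of these three substituents can be ranked above another. Nothing available here speaks to what lies behind these numbers, so the result can be described but not explained.

All three groups are substituted phenyl rings, so the compounds shown leave open whether a quite different group on this nitrogen, such as a small methyl, a benzyl or a pyridine ring, would move the number beyond the scatter. They also leave open whether the place of a substituent on the phenyl ring matters, which a pair such as 2-nitrophenyl and 4-nitrophenyl could test, and whether an amine or a carboxylic acid there would behave like the groups seen so far.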